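A few compounds are considered here, and "the series" means these few. Any claim that something is new, unique, unknown or untested is made for them only; others in the source may bear on it.

Measured compounds:
compound 1 `C=C(Br)C(=O)Nc1ccc2c(c1)/C(=C/c1cccs1)C(=O)N2`, 1700 nM;
compound 2 `C=C(Br)C(=O)Nc1ccc2c(c1)/C(=C\c1sccc1C)C(=O)N2`, 450 nM;
compound 3 `C=C(Br)C(=O)Nc1ccc2c(c1)/C(=C/c1ccc(C)s1)C(=O)N2`, 1600 nM.

In a functional assay on HeLa cells (Homo sapiens) for antiproliferative activity, read by MTT assay, with a stated time of 72 h (a lower number here means a stronger inhibitor, a higher number a weaker inhibitor), compound 3 stands second highest of the three numbers, near compound 1 and separated from compound 2 beyond the scatter. Compound 4 `C=C(Br)C(=O)Nc1ccc2c(c1)/C(=C/c1sccc1C)C(=O)N2` has not been measured; it differs from compound 3 by 3-methylthiophen-2-yl in place of 5-methylthiophen-2-yl on a double-bonded chain carbon bound to a double-bonded ring carbon. Among the compounds with values here, no measured step moves the methyl around the ring; the only step on the shared core, a 1.1-fold lower number from compound 1 to compound 3 (0.03 log units; within the scatter), stayed within the scatter. Compound 2, which also bears a 3-methylthiophen-2-yl group, gives 450 nM, which weakly points toward a lower number. Compound 4 is expected to give 800 nM, range 300 nM to 2500 nM, a step of a 2.0-fold lower number from compound 3 to compound 4 (0.30 log units; within the scatter), with low confidence.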

Compound 4, half-maximal inhibitory concentration: 420 nM
The estimate for compound 4 lay 1.9-fold (0.28 log units) above the measured number, within the range that was stated.
By their numbers in this assay, from the lowest: compounds 4 and 2 (each within the scatter of the next); then compounds 3 and 1 (each within the scatter of the next).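

In this assay the place of the methyl proves to matter: 3-methylthiophen-2-yl in place of 5-methylthiophen-2-yl gives a 3.8-fold lower number from compound 3 to compound 4 (0.58 log units; beyond the scatter) and methyl in place of hydrogen gives a 4.0-fold lower number from compound 1 to compound 4 (0.61 log units; beyond the scatter), whereas the earlier step to 5-methylthiophen-2-yl stayed within the scatter. The step of a 1.1-fold lower number from compound 2 to compound 4 (0.03 log units; within the scatter) also stays within the scatter, so the double bond as drawn separates nothing here, and one fact frames that reading: the fact that compounds 2 and 4 differ only in the configuration as drawn.

From the compounds shown here alone, it remains open whether an ethyl or a methoxy group in place of this methyl would keep the lower number.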